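The source may report more compounds than this note shows. Statements on the series, on what has been measured and on what is new or still open speak of the compounds shown alone.

Measured compounds in a functional assay on HCT-116 cells (Homo sapiens) for inhibition, read by MTT assay, with a stated time of 72 h, tested at 20 uM; a higher number here means more inhibition at the concentration tested (going by the name of the read-out), a lower number less inhibition:
compound 1 `c1cc(N2CCCC2)nc(Nc2ccc(Oc3ncnc4ccsc34)cc2)n1`, 22.2%
compound 2 `CN(c1ccc(Oc2ncnc3sccc23)cc1)c1nccc(N2CCc3ccccc3C2)n1`, 57.7%
compound 3 `CN(c1ccc(Oc2ncnc3ccsc23)cc1)c1nccc(N2CCc3ccccc3C2)n1`, 58.3%

Compound 2 stands second highest of the three; its nearest neighbour is compound 3, and the step of a number 0.6 percentage points higher from compound 2 to compound 3 (within the scatter) is within the scatter. Compound 1 lies far lower, but it differs from compound 2 in more than one place, so only its value can be compared.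

Compound 4 `CN(c1ccc(Oc2ncnc3sccc23)cc1)c1nccc(N2CCCCC2)n1` differs from compound 2 by piperidin-1-yl in place of 1,2,3,4-tetrahydroisoquinolin-2-yl on an aromatic carbon. Going by the values given here, no measured step touches this position; the only step, from compound 2 to compound 3, concerns the aryl ether and is flat. The expectation therefore rests on compound 2 alone, with wide uncertainty and no direction firmly implied.

Compound 4 is estimated at 45%, between 20% and 70%, an expected step of a number 12.7 percentage points lower from compound 2 to compound 4 (beyond the scatter).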

Compound 4, a percentage reported as inhibition, at one concentration (the size of the read-out at that concentration, not a potency): 52.2%
Estimate against measurement, compound 4: 7.2 percentage points below; the range from low to high includes it.
By their numbers in this assay, from the lowest: compound 1; then compounds 4, 2 and 3 (each within the scatter of the next).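

In this assay, going by these compounds alone, piperidin-1-yl in place of 1,2,3,4-tetrahydroisoquinolin-2-yl gives a number 5.5 percentage points lower from compound 2 to compound 4 (within the scatter), the first measured step at this position on the aromatic carbon. Within the data shown here, the inhibition at this concentration therefore holds without the six-membered aromatic ring of carbon only that leaves with the change. No measured evidence bears on why this is so.

Still open, on these data alone, is whether morpholine or an open-chain dimethylamino group at this position would give a similar read-out. Also open, as far as these compounds go, is whether piperidin-1-yl would behave the same way on the core of compound 3.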